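The source may report more compounds than this note shows. Statements on the series, on what has been measured and on what is new or still open speak of the compounds shown alone.

Three compounds share one core and were tested in a functional assay on CHO cells for agonist activity at Free fatty acid receptor 2 (Homo sapiens), read by cAMP accumulation; on this read-out higher numbers stand for weaker inhibition and lower numbers for stronger inhibition. Compound 1 `CNC(=O)[C@H](c1ccc(Cl)cc1)C(C)C` carries a methyl on the amide-type nitrogen and gives 11000 nM. Compound 2 `CC(C)[C@H](C(=O)Nc1ncc[nH]1)c1ccc(Cl)cc1` carries a 1H-imidazol-2-yl there instead and gives 20000 nM. That exchange amounts to a 1.8-fold higher number from compound 1 to compound 2 (0.26 log units; within the scatter). Compound 3 `Cc1csc(NC(=O)[C@H](c2ccc(Cl)cc2)C(C)C)n1` carries a 4-methyl-1,3-thiazol-2-yl on that nitrogen and gives 1400 nM, the lowest of the three numbers. The steps leading to it are a 7.9-fold lower number from compound 1 to compound 3 (0.90 log units; beyond the scatter) and a 14-fold lower number from compound 2 to compound 3 (1.15 log units; beyond the scatter).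

Compound 4 `CC(C)[C@H](C(=O)Nc1nc(C(C)(C)C)cs1)c1ccc(Cl)cc1` keeps everything of compound 3 except one group on the ring: tert-butyl in place of methyl on an aromatic carbon. Among the compounds with values here, none of the measured steps bears directly on this exchange; all three alter the group attached to the amide-type nitrogen, not a group on the five-membered aromatic ring with 1 nitrogen and 1 sulfur. Within the data shown here, with no step to lean on, the expected change is small, none beyond the scatter in either direction. Compound 4 is therefore expected to give 1500 nM, between 300 nM and 7500 nM. The expected step is a 1.1-fold higher number from compound 3 to compound 4 (0.03 log units; within the scatter).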

Compound 4, half-maximal inhibitory concentration: 7900 nM
Compound 4: middle estimate off by 5.3-fold (0.72 log units), on the low side; the whole stated range lies below it.
By their numbers in this assay, from the lowest: compound 3; then compounds 4, 1 and 2 (each within the scatter of the next, the first and the last beyond it).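

Within the data shown here, the earlier steps all changed the group on the amide-type nitrogen, so this is the first view of a change on the ring itself. It shows that the aromatic carbon next to the ring nitrogen is sensitive to what it carries: in this assay, tert-butyl in place of methyl gives a 5.6-fold higher number from compound 3 to compound 4 (0.75 log units; beyond the scatter), which means weaker inhibition. Nothing available explains why this exchange has that effect.

The compounds shown place only methyl and tert-butyl on this carbon, so it stays open whether the number rises steadily as carbons are added, which ethyl or isopropyl would test. As far as these compounds go, it is also open how a quite different group would behave here, such as a bare hydrogen, an amine or a carboxylic acid.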